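The source may report more compounds than this note shows. Statements on the series, on what has been measured and on what is new or still open speak of the compounds shown alone.

Working notes on the series. The two measured compounds share the core of compound 1 `Brc1ccccc1CSc1nnc(-c2ccncc2)n1-c1ccccc1`, a thioether bearing a pyridyl and a phenyl on the same ring. In a functional assay on MCF7 cells (Homo sapiens) for inhibition, read by MTT assay, with a stated time of 48 h (a higher number here means a weaker inhibitor, a lower number a stronger inhibitor), compound 1 gives 16100 nM. Compound 2 `O=C(CSc1nnc(-c2ccncc2)n1-c1ccccc1)N/N=C/c1ccccc1` replaces the benzyl group with an acyl hydrazone chain. In this assay compound 2 gives 23600 nM. That is the higher of the two numbers recorded so far, but the gap to compound 1 lies within the usual scatter, so the two compounds read as equivalent on the numbers available.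

Compound 3 `O=C(CSc1nnc(-c2ccncc2)n1-c1ccccc1)N/N=C/c1ccc(O)c(O)c1` has not yet been measured. Against compound 2 it differs in one place: 3,4-dihydroxyphenyl in place of phenyl on a carbon with a double bond to nitrogen. Among the compounds with values here, no measured pair shows this change, so there is no step to lean on, and the expectation rests on compound 2 alone. The step expected in this assay is a 1.3-fold lower number from compound 2 to compound 3 (0.12 log units; within the scatter), small, with no direction claimed beyond the scatter. For compound 3 the expected value in this assay is 18000 nM, within a range from 6000 nM to 55000 nM.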

Compound 3, half-maximal inhibitory concentration: 19700 nM
For compound 3 the middle estimate is 1.1-fold (0.04 log units) below the measured one; low and high end bracket the measured number.
By their numbers in this assay, from the lowest: compounds 1, 3 and 2 (each within the scatter of the next).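

In this assay, within the data shown here, 3,4-dihydroxyphenyl in place of phenyl on a carbon with a double bond to nitrogen gives a 1.2-fold lower number from compound 2 to compound 3 (0.08 log units; within the scatter), the first reading for this position. Here the entering group brings hydrogen-bond donors and acceptors that phenyl lacks, yet compound 3 stays within the scatter of compound 2, so this change leaves the number effectively unmoved. No measurement available bears on the reason for this result.

Going by these compounds, whether an amine or a carboxylic acid in place of 3,4-dihydroxyphenyl on this carbon would give a step beyond the scatter remains open. Also open, on these data alone, is whether a methoxy group on the phenyl would read like compound 2 and compound 3 in this assay.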